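This account rests on a few compounds, and the source may have more. Where it says the series, first, only, none or still open, it means among the compounds named here.

Three compounds share one core and differ only in the group carried on an aromatic carbon. Compound 1 `CC(C(=O)NCc1ccc(C(F)(F)Cl)nc1N1CCCCC1)c1ccc(NS(C)(=O)=O)c(F)c1` gives 1.3 nM in an assay on CHO cells for antagonist activity at transient receptor potential cation channel subfamily V member 1 (Homo sapiens), read by FLIPR; on this read-out lower numbers stand for stronger inhibition and higher numbers for weaker inhibition. Compound 2 `CC(C(=O)NCc1ccc(C(F)(F)Cl)nc1N1CCCCCC1)c1ccc(NS(C)(=O)=O)c(F)c1` gives 0.5 nM in this assay, and compound 3 `CC(C(=O)NCc1ccc(C(F)(F)Cl)nc1OCc1cccnc1)c1ccc(NS(C)(=O)=O)c(F)c1` gives 14.6 nM in this assay, the highest of the three numbers. The steps of an 11-fold higher number from compound 1 to compound 3 (1.05 log units; beyond the scatter) and a 29-fold higher number from compound 2 to compound 3 (1.47 log units; beyond the scatter) show that replacing piperidin-1-yl or azepan-1-yl with (pyridin-3-yl)methoxy weakens inhibition by a large margin. Compound 4 `CC(C(=O)NCc1ccc(C(F)(F)Cl)nc1OCc1ccccn1)c1ccc(NS(C)(=O)=O)c(F)c1` differs from compound 3 only in pyridin-2-yl in place of pyridin-3-yl on a saturated chain carbon bound to an oxygen on an aromatic ring. For the measured compounds named here, no measured step moves the pyridine nitrogen while keeping the rest of the group, so there is no direct precedent. The step is expected to stay small, a 1.0-fold higher number from compound 3 to compound 4 (0.01 log units; within the scatter), within the usual scatter. Compound 4 is therefore estimated at 15 nM, with a range from 6 nM to 40 nM.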

Compound 4, inhibition constant: 4.2 nM
Compound 4: middle estimate off by 3.6-fold (0.55 log units), on the high side; the whole stated range lies above it.
By their numbers in this assay, from the lowest: compound 2; then compound 1; then compound 4; then compound 3.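

Pyridin-2-yl in place of pyridin-3-yl gives a 3.5-fold lower number from compound 3 to compound 4 (0.54 log units; beyond the scatter) even though the two groups have the same atoms, so inhibition at this position depends on how the pyridine ring is attached, not only on which atoms it holds. The (pyridin-2-yl)methoxy group still trails the piperidin-1-yl and azepan-1-yl groups, with a 3.2-fold higher number from compound 1 to compound 4 (0.51 log units; beyond the scatter) and an 8.4-fold higher number from compound 2 to compound 4 (0.92 log units; beyond the scatter) as modest steps where compound 3 showed large ones. Nothing available explains the difference between the two pyridine attachments. The compounds shown leave open how (pyridin-4-yl)methoxy or a plain benzyloxy group would compare at this position.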